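The source may report more compounds than this note shows. Statements on the series, on what has been measured and on what is new or still open speak of the compounds shown alone.

In a functional assay on DU-145 cells (Homo sapiens) for inhibition, read by trypan blue exclusion, with a stated time of 96 h (a higher number here means a weaker inhibitor of growth, a lower number a stronger inhibitor of growth), compound 1 `Cc1ccc(C)c(/C=C(/SCc2ccc(Cl)cc2)C(=O)c2ccc(Cl)cc2)c1` gives 10000 nM. Compound 2 `CN(C)c1ccc(/C=C(/SCc2ccc(Cl)cc2)C(=O)c2ccc(Cl)cc2)cc1` gives > 100000 nM, which is a limit of the assay and not a number. Compound 3 `O=C(/C(=C\c1ccc(O)cc1)SCc1ccc(Cl)cc1)c1ccc(Cl)cc1` carries hydroxy in place of dimethylamino on an aromatic carbon, para to a large group: hydroxy in place of dimethylamino on an aromatic carbon. Within the data shown here, the one measured step that bears on this change is an at least 10-fold higher number from compound 1 to compound 2 (1.00 log units; beyond the scatter), the step that brought dimethylamino in. With that group gone, a lower number is expected, back towards the range of the first compound, and the estimated step is an at least 10-fold lower number from compound 2 to compound 3 (1.00 log units; beyond the scatter). For compound 3 the estimated value is 10000 nM, with a range of 1500 nM to 70000 nM.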

Compound 3, concentration for 50% growth inhibition: 10000 nM
Estimate against measurement, compound 3: no gap at the digits printed; low and high end bracket the measured number.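

In this assay, hydroxy in place of dimethylamino on this aromatic carbon gives an at least 10-fold lower number from compound 2 to compound 3 (1.00 log units; beyond the scatter), so the weak result of compound 2 goes with dimethylamino and not with every group at this place. Set against 2,5-dimethylphenyl, 4-hydroxyphenyl gives no change at the digits printed from compound 1 to compound 3 (within the scatter). Compound 2 stands at a limit of the assay, so the full size of the first step stays unknown: the limit of > 100000 nM in this assay, at which 1 of the 3 values shown sits.

On these data alone, whether methoxy or a simple amino group on this carbon would follow hydroxy or dimethylamino remains open. So does whether any group here could give a clearly lower number than compound 3.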